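A larger methoxy pattern on a weak scaffold

A few compounds are considered here, and "the series" means these few. Any claim that something is new, unique, unknown or untested is made for them only; others in the source may bear on it.

Measured in a functional assay on DU-145 cells (Homo sapiens) for cytotoxicity, read by MTT assay, with a stated time of 48 h; a lower number here means a stronger inhibitor, a higher number a weaker inhibitor:
- Compound 1 `COc1ccc(/C=C/C(=O)/C=C/c2cc3ccccc3nc2Oc2ccccc2)cc1`: > 10000 nM
- Compound 2 `COc1ccc(/C=C/C(=O)/C=C/c2cc3ccccc3nc2Oc2ccc(Br)cc2)cc1`: > 10000 nM

Neither entry is an exact number, since each is a limit of the assay. This gives compound 2 no exact place on the scale, and the same holds for compound 1. The shared position is the limit of > 10000 nM in this assay, at which 2 of the 2 values shown sit.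

Compound 3 `COc1cc(OC)c(/C=C/C(=O)/C=C/c2cc3ccccc3nc2Oc2ccc(Br)cc2)c(OC)c1` keeps the core of compound 2 and its bromo group. The change is 2,4,6-trimethoxyphenyl in place of 4-methoxyphenyl on a double-bonded chain carbon bound to a double-bonded chain carbon.

Going by the values given here, the one measured step, bromo in place of hydrogen on an aromatic carbon, is a step that the two limits leave unreadable from compound 1 to compound 2. It also lies at a different place in the molecule, so it offers no size to carry over to the new change.

Starting from compound 2 at > 10000 nM, which is a limit, only a modest move toward stronger inhibition is expected in this assay, and a second limit would be no surprise. The estimated step is an at least 1.4-fold lower number from compound 2 to compound 3 (0.15 log units; that floor lies within the scatter). For compound 3 the expected value is 7000 nM. The estimated range runs from 1500 nM to 30000 nM.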

Compound 3, half-maximal inhibitory concentration: > 10000 nM
Compound 3: only a limit was reported; the forecaster's own chance of this, stated with the estimate: 50%; middle value at least 1.4-fold (0.15 log units) away from the limit.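

In this assay compound 3 gives > 10000 nM, which is a limit and not a number. Compound 2 also stands at a limit, so the change from compound 2 to compound 3 cannot be read as a step, and neither can the earlier one. All three compounds share one position: the limit of > 10000 nM in this assay, at which 3 of the 3 values shown sit.

The compounds shown leave open how strong each one really is, and whether 2,4,6-trimethoxyphenyl in place of 4-methoxyphenyl changes that strength at all.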